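From 4-(trifluoromethoxy)phenyl to cyclopropylmethyl on the oxygen

The source may hold more compounds than are shown below. What is called first, only, known or untested is meant among the compounds shown, and "the series" means these compounds.

Three compounds have been measured in an assay on membranes from brain for binding affinity to Lysophosphatidylserine lipase ABHD12 (Mus musculus), read by fluorescence, with a stated time of 20 min; on this read-out higher numbers stand for weaker inhibition and lower numbers for stronger inhibition:

Compound 1 `FC(F)(F)Oc1ccc(Oc2ccnc(N3CCC(NC(=S)Nc4cccnc4)CC3)c2Cl)cc1`: 25 nM
Compound 2 `FC(F)(F)Oc1ccc(Oc2ccnc(N3CCC(NC(=S)Nc4cccnc4)CC3)c2)cc1`: 410 nM
Compound 3 `Cc1c(Oc2ccc(OC(F)(F)F)cc2)ccnc1N1CCC(NC(=S)Nc2cccnc2)CC1`: 26 nM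

Compound 2 stands at the highest number of the three, that is, it is the weakest inhibitor of the set. The step of a 16-fold higher number from compound 1 to compound 2 (1.21 log units; beyond the scatter) and the step of a 16-fold lower number from compound 2 to compound 3 (1.20 log units; beyond the scatter) both lie beyond the scatter, whereas the step of a 1.0-fold higher number from compound 1 to compound 3 (0.02 log units; within the scatter) does not.

Compound 4 `S=C(Nc1cccnc1)NC1CCN(c2cc(OCC3CC3)ccn2)CC1` has not yet been measured. It differs from compound 2 in one place: cyclopropylmethyl in place of 4-(trifluoromethoxy)phenyl on an oxygen on an aromatic ring. Every measured step in this set concerns the group on an aromatic carbon of the shared core, and none touches the group on the oxygen. So no measured step bears directly on the change from compound 2 to compound 4, and what happens when the 4-(trifluoromethoxy)phenyl group gives way to cyclopropylmethyl is unknown here. Given how much leaves relative to what enters, the step from compound 2 to compound 4 is expected to go towards a higher number, a 6.1-fold higher number from compound 2 to compound 4 (0.79 log units; beyond the scatter), but with wide uncertainty. Compound 4 is therefore estimated at 2500 nM in this assay, within a range from 300 nM to 20000 nM.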

Compound 4, half-maximal inhibitory concentration: 4700 nM
For compound 4 the middle estimate is 1.9-fold (0.27 log units) below the measured one; the range from low to high includes it.
By their numbers in this assay, from the lowest: compounds 1 and 3 (each within the scatter of the next); then compound 2; then compound 4.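

For the compounds shown here, the earlier compounds varied only the group on an aromatic carbon of the shared core, so this result is the first to show that the group on the oxygen also matters in this assay: the change gives an 11-fold higher number from compound 2 to compound 4 (1.06 log units; beyond the scatter). Replacing 4-(trifluoromethoxy)phenyl, with 11 heavy atoms and a six-membered aromatic ring, by cyclopropylmethyl, with 4 heavy atoms and a three-membered non-aromatic ring, weakens inhibition, although a number can still be read for the smaller group. Nothing shown gives a measured reason for this rise.

With a single replacement on the oxygen, the loss of the aromatic ring cannot be told apart from the loss of heavy atoms or of the trifluoromethoxy group, and an unsubstituted phenyl, a benzyl or a longer chain such as n-hexyl on that oxygen would be needed to separate them. On these data alone, it also stays open whether chloro or methyl on the aromatic carbon, which goes with lower numbers when 4-(trifluoromethoxy)phenyl sits on the oxygen, would do the same with cyclopropylmethyl there.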